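The compounds below may be only part of what the source reports. "The series", "measured", "known", "first", "only" and "open" are said of these compounds alone.

For the measured compounds named here, compound 1 `CC(C)(C)C1=NN(c2ccc(Br)cc2)C(c2ccc(O)cc2)C1` gives 93.2% in an assay on isolated protein for inhibition of protein kinase C zeta type (Homo sapiens), with a stated time of 4 min, tested at 62.5 uM (a higher number here means more inhibition at the concentration tested (going by the name of the read-out), a lower number less inhibition), the higher of the two numbers so far, while compound 2 `CC(C)(C)C1=NN(c2ccccc2F)C(c2ccc(O)cc2)C1` gives 57.6% in this assay. Going by the values given here, the one measured step, a number 35.6 percentage points lower from compound 1 to compound 2 (beyond the scatter), concerns the aryl group on the ring nitrogen and does not touch the present change. Compound 3 `Oc1ccc(C2CC(c3cccs3)=NN2c2ccc(Br)cc2)cc1` differs from compound 1 by thiophen-2-yl in place of tert-butyl on a carbon with a double bond to nitrogen. Among the compounds with values here, no measured step covers this position, so the size of the change in this assay cannot be read from the series. An expected step of a number 18.2 percentage points lower from compound 1 to compound 3 (beyond the scatter) is set with a wide range since compound 1 already stands at 93.2%. For compound 3 the estimate in this assay is 75%, between 45% and 95%.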

Compound 3, a percentage reported as inhibition, at one concentration (the size of the read-out at that concentration, not a potency): 95.2%
Estimate against measurement, compound 3: 20.2 percentage points below; measured number outside the range, above it.
By their numbers in this assay, from the lowest: compound 2; then compounds 1 and 3 (each within the scatter of the next).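

At this position on a carbon with a double bond to nitrogen, thiophen-2-yl and tert-butyl are not told apart in this assay (a number 2 percentage points higher from compound 1 to compound 3 (within the scatter)), so a five-membered aromatic ring is accepted here without loss of inhibition. Both numbers lie near the top of the scale at a single concentration, so any difference between the two groups in the size of the effect cannot be read from them. Nothing available bears on why the two groups read alike.

Still open, going by these compounds, is how a phenyl group, an amine or a carboxylic acid would read at this position. Also open, on these data alone, is whether thiophen-2-yl reads the same alongside the 2-fluorophenyl group of compound 2, where the number leaves more room to move.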